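This account rests on a few compounds, and the source may have more. Where it says the series, first, only, none or still open, it means among the compounds named here.

Measured compounds and their values:

Compound 1 `CC1=C(C(=O)Nc2ccc(Br)cc2)C(c2ccc(Cl)cc2Cl)N=C(SCc2ccccc2Cl)N1`: 11.8%
Compound 2 `CC1=C(C(=O)Nc2ccc(Br)cc2)C(c2ccc(Cl)cc2Cl)N=C(SCc2cccc(Cl)c2)N1`: 6.2%
Compound 3 `CC1=C(C(=O)Nc2ccc([N+](=O)[O-])cc2)C(c2ccc(Br)cc2)N=C(SCc2ccccc2Cl)N1`: 6.7%

All three were tested in a functional assay on the whole organism (artery, strain albino) with Rattus norvegicus as the target, with a stated time of 60 min, at a dose of 10 mg/kg by the oral route; on this read-out lower numbers stand for less inhibition and higher numbers for more inhibition at the one dose given (going by the name of the read-out). Compound 1 and compound 2 share a core and differ in one place: 3-chlorophenyl in place of 2-chlorophenyl on a saturated chain carbon bound to a sulfur. That change gave a number 5.6 percentage points lower from compound 1 to compound 2 (within the scatter). Compound 3 carries a different core; how it differs from compound 1 is not broken down here, and the two values simply stand near each other in the same low region.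

Compound 4 `CC1=C(C(=O)Nc2ccc([N+](=O)[O-])cc2)C(c2ccc(Br)cc2)N=C(SCc2cccc(Cl)c2)N1` has not been measured in this assay. It stands to compound 3 as compound 2 stands to compound 1: 3-chlorophenyl in place of 2-chlorophenyl on a saturated chain carbon bound to a sulfur. The place is the same in both pairs, so this is the same change made a second time. Among the measured compounds shown here, only one earlier instance exists, and it stayed within the scatter, so the expected step from compound 3 to compound 4 is small and of similar size, about a number 2.7 percentage points lower from compound 3 to compound 4 (within the scatter), resting on the step from compound 1 to compound 2 a number 5.6 percentage points lower from compound 1 to compound 2 (within the scatter). Compound 4 is therefore expected to give about 4% in this assay, with a range from -8% to 16%.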

Compound 4, a percentage reported as inhibition, in the whole organism at one dose (the size of the read-out at that dose, not a potency): 4.1%
Compound 4: the middle estimate sits 0.1 percentage points below what was measured; low and high end bracket the measured number.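

In this assay, 3-chlorophenyl in place of 2-chlorophenyl on a saturated chain carbon bound to a sulfur gave a number 2.6 percentage points lower from compound 3 to compound 4 (within the scatter). Set beside the earlier instance, the step on the second core does not differ from the one on the first, so in these two pairs the change carries from one core to the other without a detectable difference: the same change on two cores in this assay, a number 5.6 percentage points lower (within the scatter) from compound 1 to compound 2 and a number 2.6 percentage points lower (within the scatter) from compound 3 to compound 4, 3 percentage points apart, within the scatter of two such steps. This does not show that the change has a real effect of its own, as neither step lies beyond the scatter, and two cores cannot speak for the whole series.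

From the compounds shown here alone, all four compounds carry a chlorophenyl on the saturated chain carbon bound to a sulfur, so what an amine, a carboxylic acid or a longer chain would give in that place stays open. Also open, going by these compounds, is whether the same step would hold on a core whose value lies well clear of this low region.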